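Aryl-isoxazole ethers: amine swap on the chain

A few compounds are considered here, and "the series" means these few. Any claim that something is new, unique, unknown or untested is made for them only; others in the source may bear on it.

Measured so far in an assay on isolated protein for inhibition of C-X-C chemokine receptor type 1 (Homo sapiens), read by radioligand binding; on this read-out higher numbers stand for weaker inhibition and lower numbers for stronger inhibition:
compound 1 `CN(C)COc1ccc(-c2cc(-c3ccc(Cl)cc3)on2)cc1`: 2700 nM
compound 2 `CN1CCN(COc2ccc(-c3cc(-c4ccc(Cl)cc4)on3)cc2)CC1`: 1600 nM
compound 3 `CN(C)CCCOc1ccc(-c2cc(-c3ccc(Cl)cc3)no2)cc1`: 3900 nM

Compound 1 and compound 2 share a core and differ by 4-methylpiperazin-1-yl in place of dimethylamino on a saturated chain carbon bound to an oxygen on an aromatic ring. That change gave a 1.7-fold lower number from compound 1 to compound 2 (0.23 log units; within the scatter). Compound 3 carries a different core; how it differs from the core of compound 1 is not broken down here, and its value stands beside those of compound 1 and compound 2 as given above.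

Compound 4 `CN1CCN(CCCOc2ccc(-c3cc(-c4ccc(Cl)cc4)no3)cc2)CC1` is not yet measured. It differs from compound 3 by 4-methylpiperazin-1-yl in place of dimethylamino on a saturated chain carbon, three bonds along the chain from an oxygen on an aromatic ring. This is the same kind of change as from compound 1 to compound 2, but at a different place: there the carbon is bound to an oxygen on an aromatic ring, here it sits three bonds along the chain from that oxygen.

Among the compounds with values here, for compound 4 the expected step is a 1.6-fold lower number from compound 3 to compound 4 (0.21 log units; within the scatter), which rests on the step of a 1.7-fold lower number from compound 1 to compound 2 (0.23 log units; within the scatter), the only measured instance of this change. Compound 4 is therefore estimated at 2400 nM in this assay, with a range from 1000 nM to 5500 nM.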

Compound 4, half-maximal inhibitory concentration: 2100 nM
For compound 4 the middle estimate is 1.1-fold (0.06 log units) above the measured one; the measured number falls inside the stated range.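

In this assay, 4-methylpiperazin-1-yl in place of dimethylamino gives a 1.9-fold lower number from compound 3 to compound 4 (0.27 log units; within the scatter), and this sits close to the earlier step: the same change on two cores in this assay, a 1.7-fold lower number (0.23 log units; within the scatter) from compound 1 to compound 2 and a 1.9-fold lower number (0.27 log units; within the scatter) from compound 3 to compound 4, 1.1-fold (0.04 log units) apart, within the scatter of two such steps. The change therefore reads alike on these two cores, with no difference in size that can be told apart from the scatter. Each step on its own lies within the scatter, so the pair does not establish a real effect of the change, and two cores say nothing about how it would read on others.

Open, going by these compounds, is whether another amine on the chain, such as morpholine or piperidine, would give a step beyond the scatter. Also open, on these data alone, is how a carboxylic acid in place of the amine would read in this assay.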